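This account rests on a few compounds, and the source may have more. Where it says the series, first, only, none or still open, it means among the compounds named here.

Measured in a functional assay on MOLT-4 cells (Homo sapiens) for antiproliferative activity, read by CCK-8 assay, with a stated time of 72 h; on this read-out lower numbers stand for stronger inhibition and higher numbers for weaker inhibition:
- compound 1 `Cc1cc(Nc2cc(N3CCN(C)CC3)nc(Nc3cccc([N+](=O)[O-])c3)n2)n[nH]1`: 26 nM
- compound 2 `Cc1cc(Nc2cc(N3CCN(C)CC3)nc(Nc3ccc(S(N)(=O)=O)cc3)n2)n[nH]1`: 648 nM
- compound 3 `COc1ccc(Nc2nc(Nc3cc(C)[nH]n3)cc(N3CCN(C)CC3)n2)cc1`: 116 nM

Compound 3 stands second highest of the three numbers in this assay, with compound 1 nearer and compound 2 further away. Compound 4 `COc1cccc(Nc2nc(Nc3cc(C)[nH]n3)cc(N3CCN(C)CC3)n2)c1` differs from it by 3-methoxyphenyl in place of 4-methoxyphenyl on a nitrogen on an aromatic ring. For the measured compounds named here, no measured step moves a methoxy group between these two positions; the step that comes closest is a 4.5-fold higher number from compound 1 to compound 3 (0.65 log units; beyond the scatter), where the aryl group carrying a substituent at the 3-position sits at the lower number, and a 25-fold higher number from compound 1 to compound 2 (1.40 log units; beyond the scatter) points the same way. A small to modest lower number is therefore expected for compound 4, estimated at 70 nM (range 30 nM to 180 nM), a step of a 1.7-fold lower number from compound 3 to compound 4 (0.22 log units; within the scatter) from compound 3, though it could also fall within the scatter.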

Compound 4, half-maximal inhibitory concentration: 192 nM
Compound 4: the middle estimate sits 2.7-fold (0.44 log units) below what was measured; measured number outside the range, above it.
By their numbers in this assay, from the lowest: compound 1; then compounds 3 and 4 (each within the scatter of the next); then compound 2.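

In this assay, moving the methoxy group from 4-methoxyphenyl to 3-methoxyphenyl gives a 1.7-fold higher number from compound 3 to compound 4 (0.22 log units; within the scatter) and so does not separate the two placements. The 3-position alone does not account for the low number of compound 1: methoxy in place of nitro gives a 7.4-fold higher number from compound 1 to compound 4 (0.87 log units; beyond the scatter) while 3-methoxyphenyl in place of 4-sulfamoylphenyl gives a 3.4-fold lower number from compound 2 to compound 4 (0.53 log units; beyond the scatter) on the same core. Nothing available explains these steps.

Open, as far as these compounds go, is whether another group at the 3-position, such as an amine or a carboxylic acid, would come close to nitro. Also open, from the compounds shown here alone, is how 4-nitrophenyl and 3-sulfamoylphenyl would read, which would separate the effect of the group from that of its position.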